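A few compounds are considered here, and "the series" means these few. Any claim that something is new, unique, unknown or untested is made for them only; others in the source may bear on it.

Measured so far in an assay on Sf9 cells for inhibition of 1-acyl-sn-glycerol-3-phosphate acyltransferase beta (Homo sapiens); on this read-out lower numbers stand for stronger inhibition and higher numbers for weaker inhibition:
compound 1 `Cc1ccc(Cl)cc1-c1cc(Nc2ccc(Br)cc2)nc(N)n1` — 34 nM
compound 2 `Cc1ccc(Cl)cc1-c1cc(Nc2cccc(Br)c2)nc(N)n1` — 610 nM

For the measured compounds named here, compound 1 gives the lowest number of the two; the one step measured so far is an 18-fold higher number from compound 1 to compound 2 (1.25 log units; beyond the scatter), a large one, and it is the only comparison available. Compound 3 `Cc1ccc(Cl)cc1-c1cc(Nc2ccc(C(F)(F)F)cc2)nc(N)n1` has not been measured. It differs from compound 1 in one place: trifluoromethyl in place of bromo on an aromatic carbon. The measured step moves the bromo substituent to another position of the same ring while keeping the group itself; it says nothing about exchanging bromo for trifluoromethyl, so it bears on the present change only in showing that this part of the structure matters in this assay. Going by the values given here, with no step that exchanges one substituent for another, the expected outcome is a step from compound 1 to compound 3 of a 1.5-fold higher number from compound 1 to compound 3 (0.17 log units; within the scatter), that is, no change beyond the scatter, with the direction left open. Compound 3 is therefore estimated at 50 nM, with a range from 15 nM to 170 nM.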

Compound 3, half-maximal inhibitory concentration: 140 nM
Estimate against measurement, compound 3: 2.8-fold (0.45 log units) below; the range from low to high includes it.
By their numbers in this assay, from the lowest: compound 1; then compound 3; then compound 2.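

In this assay the result adds a second kind of sensitivity at this ring: the earlier step, an 18-fold higher number from compound 1 to compound 2 (1.25 log units; beyond the scatter), moved bromo and kept the group, whereas the new one changes the group and keeps its place, para to a large group. Trifluoromethyl in place of bromo gives a 4.1-fold higher number from compound 1 to compound 3 (0.61 log units; beyond the scatter), so the identity of the substituent at this place also matters, and bromo remains the better of the two groups compared here on this read-out. Nothing available explains why the number rises with this exchange.

On these data alone, it remains open how far this preference extends, since two groups at one place do not define a trend: chloro, a nitrile, a methoxy group, an amine or a carboxylic acid there could each fall close to compound 1 or well away from it. Also unsettled is whether trifluoromethyl loses as much or less when it sits where bromo sits in compound 2, which would show whether the effects of group and place act independently.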